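Agonists at GPR39: swapping the carbamoyl for an ether

The source may report more compounds than this note shows. Statements on the series, on what has been measured and on what is new or still open speak of the compounds shown alone.

Measured so far:
compound 1 `Cc1nn(-c2ncnc3nc[nH]c23)c2c1C(OCc1ccc(Cl)cc1Cl)CC(=O)N2` — 4 nM
compound 2 `Cc1nn(-c2ncnc3nc[nH]c23)c2c1C(C(=O)NCc1ccccc1)CC(=O)N2` — 5 nM
compound 3 `Cc1nn(-c2ncnc3nc[nH]c23)c2c1C(C(=O)N(C)c1nccs1)CC(=O)N2` — 18 nM

Of the compounds shown here, three sharing one core have been tested in a functional assay on HEK293 cells for agonist activity at G-protein coupled receptor 39 (Homo sapiens), read by scintillation proximity assay and inositol phosphate accumulation, with a stated time of 75 min, in the presence of a further agent that is not named here; a lower number here means that less compound is needed, a higher number that more compound is needed for the effect. Compound 1 gives 4 nM and compound 2 gives 5 nM; the step of a 1.3-fold higher number from compound 1 to compound 2 (0.10 log units; within the scatter) lies within the scatter. Compound 3 gives 18 nM, the highest of the three numbers; the steps of a 4.5-fold higher number from compound 1 to compound 3 (0.65 log units; beyond the scatter) and a 3.6-fold higher number from compound 2 to compound 3 (0.56 log units; beyond the scatter) are both beyond the scatter, so compound 3 needs modestly more material than the other two.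

Compound 4 `Cc1nn(-c2ncnc3nc[nH]c23)c2c1C(OCC(C)C)CC(=O)N2` is the next candidate. Its change from compound 3 is isobutoxy in place of methyl(1,3-thiazol-2-yl)carbamoyl on a saturated ring carbon. The step that bears most on this is a 4.5-fold higher number from compound 1 to compound 3 (0.65 log units; beyond the scatter), since compound 1 also carries an ether at the same saturated ring carbon, though with a different group. A reversal of that step is therefore expected, at least in part, and the step of a 2.0-fold lower number from compound 3 to compound 4 (0.30 log units; within the scatter) is the estimate. The difference between isobutoxy and (2,4-dichlorobenzyl)oxy is not covered by any measured pair, which widens the range. Compound 4 is expected to give about 9 nM, between 3 nM and 35 nM.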

Compound 4, half-maximal effective concentration: 4 nM
Estimate against measurement, compound 4: 2.3-fold (0.35 log units) above; the range from low to high includes it.
By their numbers in this assay, from the lowest: compounds 1, 4 and 2 (each within the scatter of the next); then compound 3.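

Exchanging 2,4-dichlorophenyl for isopropyl on the saturated chain carbon bound to an oxygen gives no measurable shift in this assay (no change at the digits printed from compound 1 to compound 4 (within the scatter)), so within these two ethers the aromatic ring and its two chlorines are not needed for this read-out. The isobutoxy group, which has no ring, also differs clearly from the larger methyl(1,3-thiazol-2-yl)carbamoyl group at the same saturated ring carbon (a 4.5-fold lower number from compound 3 to compound 4 (0.65 log units; beyond the scatter)), yet it stands level with the benzylcarbamoyl group (a 1.3-fold lower number from compound 2 to compound 4 (0.10 log units; within the scatter)). Across the four compounds, the two ethers and the benzylcarbamoyl compound therefore lie within the scatter of one another, and only the methyl(1,3-thiazol-2-yl)carbamoyl compound stands apart. Nothing shown here accounts for these differences or for the gap left by that one group.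

The compounds shown leave open how far the ether chain can be shortened, as a methoxy group at this carbon would test, and whether a plain benzyloxy group would match the 2,4-dichlorobenzyl ether. They also leave open whether an amine or a carboxylic acid at this saturated ring carbon would fit alongside the ethers and the benzylcarbamoyl group.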